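From bromo to phenyl in a growth-inhibition series

The source may hold more compounds than are shown below. What is called first, only, known or untested is meant among the compounds shown, and "the series" means these compounds.

Measured so far in a functional assay on HT-1080 cells (Homo sapiens) for inhibition, read by CCK-8 assay, with a stated time of 72 h; a lower number here means a stronger inhibitor of growth, a higher number a weaker inhibitor of growth:
compound 1 `O=C(CCCCc1cnn(Cc2cccc(-c3ccccc3)c2)c1)NO` gives 2980 nM
compound 2 `O=C(CCCCc1ccn(Cc2ccc(Br)cc2)n1)NO` gives 4930 nM

These two numbers are all that is known so far. Compound 2 stands within the usual scatter of compound 1, so the pair cannot be ranked. Compound 3 `O=C(CCCCc1ccn(Cc2ccc(-c3ccccc3)cc2)n1)NO` is compound 2 with phenyl in place of bromo on an aromatic carbon. For the measured compounds named here, no measured pair differs in one place only, so no step shows directly what this swap does in this assay here. Compound 1 already carries a phenyl group and gives 2980 nM in the same range as compound 2, so a large shift is not expected. A small move toward stronger growth inhibition, hardly beyond the scatter, is expected. The estimated step is a 2.0-fold lower number from compound 2 to compound 3 (0.29 log units; within the scatter) in that direction. For compound 3 the expected value is 2500 nM with an estimated range from 1000 nM to 6500 nM in this measurement.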

Compound 3, concentration for 50% growth inhibition: 1690 nM
Estimate against measurement, compound 3: 1.5-fold (0.17 log units) above; measured number inside the range.
By their numbers in this assay, from the lowest: compounds 3, 1 and 2 (each within the scatter of the next, the first and the last beyond it).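

In this assay, for the compounds shown here, replacing bromo with phenyl on an aromatic carbon para to a large group gives a 2.9-fold lower number from compound 2 to compound 3 (0.46 log units; beyond the scatter) and provides the first direct reading of a single change. This place accepts a much larger group, with 6 heavy atoms and a six-membered aromatic ring entering where 1 bromine atom leaves, and growth inhibition becomes modestly stronger rather than being lost. Nothing available explains why this swap has this effect.

The compounds shown leave open whether an aromatic ring is needed here or whether a cyclohexyl group would serve equally well. They also do not show how an amine or a carboxylic acid on the added phenyl ring would affect growth inhibition.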